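Shifting a Fluorine Atom: From Compound 2 to Compound 4

A few compounds are considered here, and "the series" means these few. Any claim that something is new, unique, unknown or untested is made for them only; others in the source may bear on it.

In a functional assay on ECa-109 cells (Homo sapiens) for inhibition, read by MTT assay, with a stated time of 72 h (on this read-out higher numbers stand for weaker inhibition and lower numbers for stronger inhibition), compound 2 `Fc1ccc(Cn2cc(CSC(=S)N3CCNCC3)nn2)cc1` is known only by a limit, > 128000 nM, so no number places it among the others. Of the three values shown, two are such limits and one is a number; the limit of > 128000 nM in this assay, at which 2 of the 3 values shown sit, records where those limits sit. Compound 1 `CC(C)(C)OC(=O)N1CCN(C(=S)SCc2cn(-c3ccccc3F)nn2)CC1` also reaches only the limit > 128000 nM. Compound 3 `COc1ccc(Cn2cc(CSC(=S)N3CCN(C(=O)OCc4ccccc4)CC3)nn2)cc1` gives a measured value of 58300 nM in this assay. Compound 4 `Fc1ccccc1Cn1cc(CSC(=S)N2CCNCC2)nn1` arises from compound 2 by one change: 2-fluorophenyl in place of 4-fluorophenyl on a saturated chain carbon bound to an aromatic nitrogen. Going by the values given here, no step between measured compounds is available, so the size of this change cannot be read from the data. Compound 1 carries the same 2-fluorophenyl group. Compound 4 is therefore expected to show no step beyond the scatter, a step that the limit leaves unreadable from compound 2 to compound 4, and most likely a limit again. The estimate for compound 4 is 150000 nM, between 60000 nM and 350000 nM.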

Compound 4, half-maximal inhibitory concentration: > 128000 nM
Compound 4 gave a limit, no number; the forecaster's own chance of this, stated with the estimate: 75%; the middle value is on the limit's open side.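

Compound 2 and compound 4 are both known only as limits, so no step between them can be read: the limit of > 128000 nM in this assay, at which 3 of the 4 values shown sit.

The compounds shown leave open whether 2-fluorophenyl and 4-fluorophenyl on this shared core differ in inhibition at all.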